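A few compounds are considered here, and "the series" means these few. Any claim that something is new, unique, unknown or untested is made for them only; others in the source may bear on it.

Measured in an ADME assay on LLC-MK2 cells (Macaca mulatta) for cytotoxicity, read by spectrophotometry and crystal violet staining, with a stated time of 4 days; a lower number here means that less compound is tolerated, a higher number that more compound is tolerated:
- compound 1 `CC(C)n1ncc2c(C(=O)Nc3ccc(F)cc3)cc(-c3cccs3)nc21`: > 200000 nM, a limit of the assay and not a number
- compound 2 `CC(C)n1ncc2c(C(=O)Nc3ncccn3)cc(-c3cccs3)nc21`: 75000 nM
- compound 3 `CC(C)n1ncc2c(C(=O)N3CCc4cccnc43)cc(-c3cccs3)nc21`: 50000 nM

Among the compounds with values here, only two true numbers exist in this small set, and they cannot be told apart: the gap is a 1.5-fold lower number from compound 2 to compound 3 (0.18 log units; within the scatter). Compound 3 therefore sits level with compound 2, and both lie clearly under the limit reached by compound 1, as an at least 4.0-fold lower number from compound 1 to compound 3 (0.60 log units; beyond the scatter) shows.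

Compound 4 `CC(C)n1ncc2c(C(=O)Nc3ccccc3F)cc(-c3cccs3)nc21` differs from compound 3 by one swap: a group of 8 heavy atoms (6 carbon, 1 nitrogen, 1 fluorine; one six-membered aromatic ring of carbon only) in place of a group of 9 heavy atoms (7 carbon, 2 nitrogen; one five-membered non-aromatic ring with 1 hetero atom, one six-membered aromatic ring with 1 hetero atom), on a carbonyl carbon. The group that enters is (2-fluorophenyl)amino.

The most useful guide is an at least 4.0-fold lower number from compound 1 to compound 3 (0.60 log units; beyond the scatter), read backwards. Compound 1 carries 4-fluorophenyl on the amide nitrogen, much as compound 4 carries 2-fluorophenyl, so the swap from compound 3 to compound 4 nearly undoes that step. The fluorine sits differently, though, and a single comparison is thin support. A higher number in this assay is therefore expected, meaning more compound tolerated, and the expected change is a 3.0-fold higher number from compound 3 to compound 4 (0.48 log units; beyond the scatter). The assay may again report only a limit. For compound 4 the estimated value is 150000 nM, with an expected range of 70000 nM to 260000 nM.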

Compound 4, half-maximal cytotoxic concentration: 50000 nM
The estimate for compound 4 lay 3.0-fold (0.48 log units) above the measured number; measured number below the stated range.
By their numbers in this assay, from the lowest: compounds 3, 4 and 2 (each within the scatter of the next). At a limit, above all of these: compound 1.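

In this assay, (2-fluorophenyl)amino on the carbonyl carbon gives no change at the digits printed from compound 3 to compound 4 (within the scatter), and 2-fluorophenyl in place of pyrimidin-2-yl gives a 1.5-fold lower number from compound 2 to compound 4 (0.18 log units; within the scatter), so neither swap shows a measurable change, even though the first restores the amide hydrogen and the second leaves a ring of carbon only. The new information comes from the pair that differs only in the place of the fluorine on the phenyl ring, where 2-fluorophenyl in place of 4-fluorophenyl gives an at least 4.0-fold lower number from compound 1 to compound 4 (0.60 log units; beyond the scatter), so having a fluorophenyl group on the amide nitrogen is not enough to reach the level of compound 1. Compound 1 remains the only compound at a limit of the assay, which is not a number: the limit of > 200000 nM in this assay, at which 1 of the 4 values shown sits.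

Within the data shown here, the true size of the gap to compound 1 stays unknown, and this single pair cannot show whether the 4-fluorophenyl group is special or the 2-fluorophenyl group is the one that lowers the number. A plain phenyl or a 4-chlorophenyl group on the same amide nitrogen would be needed to tell these readings apart.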